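The source may hold more compounds than are shown below. What is called first, only, known or untested is meant among the compounds shown, and "the series" means these compounds.

Working notes on the step from compound 2 (`COc1cc(NC(C)CCCNC(=O)NN)c2ncccc2c1`). In a functional assay on NCI-H460 cells (Homo sapiens) for inhibition, read by MTT assay, with a stated time of 4 days (a higher number here means a weaker inhibitor, a lower number a stronger inhibitor), compound 2 gives > 100000 nM, which is a limit and not a number. Compound 1 (`COc1cc(NC(C)CCCNC(=O)NNC(=O)NCCCCCO)c2ncccc2c1`) gives > 100000 nM in this assay, also a limit. Compound 3 (`COc1cc(NC(C)CCCNC(=O)NNC(=O)NCCO)c2ncccc2c1`) differs from compound 2 by (2-hydroxyethyl)carbamoyl in place of hydrogen on an amine nitrogen. Among the measured compounds shown here, one measured step bears on this change: a step that the two limits leave unreadable from compound 1 to compound 2. Its size cannot be read, and the evidence is only (the limit of > 100000 nM in this assay, at which 2 of the 2 values shown sit). With no readable step to carry over, no change beyond the scatter is expected in this assay. The expected step is a number no higher from compound 2 to compound 3 (the limit leaves the size open), with no settled direction. Compound 3 is estimated at 100000 nM, with an expected range of 40000 nM to 200000 nM, and a reported limit is more likely than a number.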

Compound 3, half-maximal inhibitory concentration: > 100000 nM
Compound 3 was reported as a limit; the forecaster's own chance of this, stated with the estimate: 80%; the middle value sits exactly at the limit.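

In this assay compound 3 gives > 100000 nM as a limit and not a number. Among the compounds shown here, no step among compound 1, compound 2 and compound 3 can be read. The compounds shown leave open whether (2-hydroxyethyl)carbamoyl or (5-hydroxypentyl)carbamoyl in place of hydrogen changes inhibition at all.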